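Trifluoromethyl for Methyl: Expected Tolerance of Compound 4

The source may report more compounds than this note shows. Statements on the series, on what has been measured and on what is new or still open speak of the compounds shown alone.

Three compounds have been measured in a toxicity assay on A549 cells (Homo sapiens) for cytotoxicity, read by luminescence and CellTiter-Glo, with a stated time of 48 h; a higher number here means that more compound is tolerated, a lower number that less compound is tolerated:

Compound 1, `Fc1ccc(-c2nc3ncccn3c2NC2CCCCC2)cc1`, gives 100000 nM.
Compound 2, `COc1ccc(-c2nc3ncccn3c2NC2CCCCC2)cc1`, gives > 100000 nM, which is a limit of the assay.
Compound 3, `Cc1cc(Br)ccc1-c1nc2ncccn2c1NC1CCCCC1`, gives 45000 nM.

Compound 3 holds the lowest of the two numbers shown in this assay; its nearest neighbour is compound 1, and the step of a 2.2-fold lower number from compound 1 to compound 3 (0.35 log units; beyond the scatter) is a modest lowering. Compound 2 sits at the limit (the limit of > 100000 nM in this assay, at which 1 of the 3 values shown sits), so the step of an at least 2.2-fold lower number from compound 2 to compound 3 (0.34 log units; beyond the scatter) can only be given as at least modest. For the measured compounds named here, both steps swap the whole aryl group on the shared core, and no measured step changes a single substituent on the phenyl ring.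

Compound 4, `FC(F)(F)c1cc(Br)ccc1-c1nc2ncccn2c1NC1CCCCC1`, differs from compound 3 by trifluoromethyl in place of methyl on an aromatic carbon. Going by the values given here, none of the measured steps bear directly on this change; the available steps into compound 3 were modest and pointed downward, while the shared core and the bromo group stay the same. A step in this assay of no more than modest size is therefore expected, and its direction is uncertain. The estimated step is a 1.3-fold lower number from compound 3 to compound 4 (0.11 log units; within the scatter). For compound 4 the expected value in this assay is 35000 nM, within a range from 15000 nM to 90000 nM.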

Compound 4, half-maximal cytotoxic concentration: 25000 nM
For compound 4 the middle estimate is 1.4-fold (0.15 log units) above the measured one, within the range that was stated.
By their numbers in this assay, from the lowest: compounds 4 and 3 (each within the scatter of the next); then compound 1.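

At the aromatic carbon ortho to a large group and meta to a bromo group, trifluoromethyl in place of methyl gives a 1.8-fold lower number from compound 3 to compound 4 (0.26 log units; within the scatter) in this assay, and this is the only step shown at this position. A group of 4 heavy atoms thus takes the place of a group of 1 heavy atom, yet the two numbers cannot be told apart, so for this pair, on this core and with the bromo group kept, the swap leaves no readable difference in cytotoxicity. No measured information shown here offers a reason for this result.

Methyl and trifluoromethyl are the only two groups shown at this position, so it remains open whether an amine, a carboxylic acid or a longer chain such as propyl would also leave the number within the scatter of compound 3. The same swap is also shown only with the bromo group in place, so its outcome on a phenyl ring carrying fluoro or methoxy instead remains unknown.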